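A Side Chain Swap and Growth Inhibition

A few compounds are considered here, and "the series" means these few. Any claim that something is new, unique, unknown or untested is made for them only; others in the source may bear on it.

In a functional assay on HCT-15 cells (Homo sapiens) for antiproliferative activity, read by sulforhodamine B assay (a lower number here means a stronger inhibitor of growth, a higher number a weaker inhibitor of growth), compound 1 (`CC(C)(C)CCOc1cccc(O)c1C(=O)/C=C/c1ccc(O)cc1`) gives 3430 nM as a true number. Compound 2 (`CC(C)=CCOc1cccc(O)c1C(=O)/C=C/c1ccc(O)cc1`) reads > 30000 nM and this is a limit of the assay, not a number. Going by the values given here, the one measured step is an at least 8.7-fold higher number from compound 1 to compound 2 (0.94 log units; beyond the scatter) when 2-methylprop-1-en-1-yl takes the place of neopentyl, and it lies beyond the scatter.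

Compound 3 (`O=C(/C=C/c1ccc(O)cc1)c1c(O)cccc1OCCC1CCCCC1`) is still unmeasured. It carries cyclohexylmethyl in place of 2-methylprop-1-en-1-yl on a saturated chain carbon bound to an oxygen on an aromatic ring. This removes the double bond, so a return towards compound 1 at 3430 nM is expected, a change of similar size to the measured step but reversed. In this assay the expected step is an at least 7.5-fold lower number from compound 2 to compound 3 (0.87 log units; beyond the scatter) with stronger growth inhibition. The estimate for compound 3 is 4000 nM with an expected range of 1200 nM to 15000 nM once tested.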

Compound 3, concentration for 50% growth inhibition: > 30000 nM
Compound 3: a limit, no number; the forecaster's own chance of this, stated with the estimate: 12%; middle value at least 7.5-fold (0.87 log units) away from the limit.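

In this assay, cyclohexyl in place of tert-butyl on a saturated chain carbon gives an at least 8.7-fold higher number from compound 1 to compound 3 (0.94 log units; beyond the scatter). The chain of compound 3 is as saturated as that of compound 1, yet it no longer gives a true number, so at this position removing the double bond of compound 2 is not enough to keep growth inhibition, and the group at the chain's end matters too. Compound 2 and compound 3 cannot be ranked against each other, and their step cannot be read, because both sit at the same limit of the assay: the limit of > 30000 nM in this assay, at which 2 of the 3 values shown sit.

On these data alone, how far beyond that limit either compound lies remains unknown. The compounds shown also leave open how a plain straight pentyl chain, or a chain ending in an amine, would behave at this position.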